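Removing One Chloro Group from Compound 2

The source may report more compounds than this note shows. Statements on the series, on what has been measured and on what is new or still open speak of the compounds shown alone.

Compound 1 `NC(=O)c1ccc2c(c1)CCOC2CCN1CC=C(c2csc3cc(F)ccc23)CC1`: 20 nM
Compound 2 `NC(=O)c1ccc2c(c1)CCOC2CCN1CC=C(c2c[nH]c3c(Cl)c(Cl)ccc23)CC1`: 165 nM

Of the two compounds measured in an assay on cells for binding affinity to 5-hydroxytryptamine receptor 1D (Homo sapiens), read by radioligand binding (on this read-out lower numbers stand for stronger inhibition and higher numbers for weaker inhibition), compound 2 stands at the higher number, beyond the scatter from compound 1. Compound 3 `NC(=O)c1ccc2c(c1)CCOC2CCN1CC=C(c2c[nH]c3cc(Cl)ccc23)CC1` differs from compound 2 in one place: hydrogen in place of chloro on an aromatic carbon. Within the data shown here, no measured pair shows a step of this kind, so only a modest step is expected, if any, toward a lower number. Compound 3 is expected to give 100 nM in this assay, with a range from 30 nM to 400 nM. That estimate means an expected step of a 1.7-fold lower number from compound 2 to compound 3 (0.22 log units; within the scatter).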

Compound 3, inhibition constant: 145 nM
The estimate for compound 3 lay 1.5-fold (0.16 log units) below the measured number, within the range that was stated.
By their numbers in this assay, from the lowest: compound 1; then compounds 3 and 2 (each within the scatter of the next).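

Hydrogen in place of chloro on this aromatic carbon, ortho to a chloro group, gives a 1.1-fold lower number from compound 2 to compound 3 (0.06 log units; within the scatter) in this assay, so this change on its own does not move the number beyond the scatter. A step beyond the scatter comes instead with 6-chloro-1H-indol-3-yl in place of 6-fluoro-1-benzothiophen-3-yl, a 7.3-fold higher number from compound 1 to compound 3 (0.86 log units; beyond the scatter). No evidence at hand accounts for either step. Left open is whether a methoxy group or an amine on this same carbon would shift the number, and what hydrogen in place of the remaining chloro group would do.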